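Swapping a Bulky Group for a Smaller One

A few compounds are considered here, and "the series" means these few. Any claim that something is new, unique, unknown or untested is made for them only; others in the source may bear on it.

Measured compounds:
compound 1 `CN1CCN(c2nc3cc(C(C)(C)C)ccc3o2)CC1`: < 4
compound 2 `CCc1cccc2nc(N3CCN(C)CC3)oc12`: 5.48
compound 3 `Cc1cc(C)c2oc(N3CCN(C)CC3)nc2c1`: 6.32

Three compounds sharing one core were tested in a functional assay on ileum (strain Hartley) for agonist activity at 5-hydroxytryptamine receptor 3A (Cavia porcellus); on this read-out lower numbers stand for lower potency and higher numbers for higher potency (the scale is a negative logarithm). Compound 1 gave only a limit, < 4, and not a measured number, so it sits at the limit of < 4 in this assay, at which 1 of the 3 values shown sits. Compound 2 gave 5.48 in this assay, and compound 3 gave 6.32.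

The unmeasured compound 4 `CCc1ccc2oc(N3CCN(C)CC3)nc2c1` differs from compound 1 in one place: ethyl in place of tert-butyl on an aromatic carbon. The group sits on an aromatic carbon of a six-membered aromatic ring of carbon only, part of a fused system of two rings, meta to a fused ring and para to a fused ring.

For the measured compounds named here, since compound 1 gives only a limit, no exact step can be measured, but the two compounds with smaller alkyl groups on the core both reached measurable potency. The step from compound 1 to compound 4 is therefore expected to be upward, a number at least 1.30 log units higher from compound 1 to compound 4 (beyond the scatter), beyond the usual scatter. For compound 4 the estimated value is 5.3, with a likely range from 4.3 to 6.3.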

Compound 4, negative logarithm of the half-maximal effective concentration: < 4
Compound 4 ended at the assay's limit; the forecaster's own chance of this, stated with the estimate: 20%; at least 1.30 log units between middle value and limit.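

Compound 1 and compound 4 both give a limit and not a measured number, so no step can be read between them: the limit of < 4 in this assay, at which 2 of the 4 values shown sit. The compounds shown leave open whether ethyl in place of tert-butyl on an aromatic carbon changes potency at all in this assay.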